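A few compounds are considered here, and "the series" means these few. Any claim that something is new, unique, unknown or untested is made for them only; others in the source may bear on it.

Going by the values given here, compound 2 `Cc1cc(C(O)Cc2ccccc2)c2cn[nH]c2c1` gives 1200 nM in an assay for binding affinity to Indoleamine 2,3-dioxygenase 1 (Homo sapiens), read by spectrophotometry, with a stated time of 30 min (a higher number here means weaker binding, a lower number tighter binding), the lowest of the two numbers measured so far. Its nearest neighbour, compound 1 `OC(Cc1ccccc1)c1cccc2[nH]ncc12`, gives 31000 nM in this assay, and the step is a 26-fold lower number from compound 1 to compound 2 (1.41 log units; beyond the scatter), a methyl in place of hydrogen on an aromatic carbon. Compound 3 `OC(Cc1ccccc1)c1cc(Br)cc2[nH]ncc12` is not yet measured; it differs from compound 2 by bromo in place of methyl on an aromatic carbon. Among the compounds with values here, no measured step exchanges one one-heavy-atom group for another at this carbon; the only step that touches this carbon, a 26-fold lower number from compound 1 to compound 2 (1.41 log units; beyond the scatter), shows that what stands there moves the number strongly. With bromo, like methyl, occupying the carbon that was bare in compound 1, the number for compound 3 is expected to stay near that of compound 2, with the step of a 1.3-fold higher number from compound 2 to compound 3 (0.10 log units; within the scatter) expected to fall within the scatter or a little beyond it. Compound 3 is therefore estimated at 1500 nM, in a range from 400 nM to 6000 nM.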

Compound 3, dissociation constant: 600 nM
Compound 3: middle estimate off by 2.5-fold (0.40 log units), on the high side; the range from low to high includes it.
By their numbers in this assay, from the lowest: compounds 3 and 2 (each within the scatter of the next); then compound 1.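

In this assay, replacing methyl with bromo on this aromatic carbon gives a 2.0-fold lower number from compound 2 to compound 3 (0.30 log units; within the scatter) and so does not separate the two groups. Bromo in place of hydrogen gives a 52-fold lower number from compound 1 to compound 3 (1.71 log units; beyond the scatter) and shows that the large fall in the number seen with methyl is not confined to that one group: two different groups of one heavy atom, each para to a fused ring, both stand far from the bare carbon of compound 1. The data shown offer no explanation for this shared result.

Going by these compounds, it remains open whether a chloro or fluoro group, an amine, a carboxylic acid or a longer chain on this carbon would keep the number as low. On these data alone, it is also open whether the same replacements would have a similar effect on other carbons of the shared core.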